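Fluoro added to the phenyl ring of compound 3

The compounds below may be only part of what the source reports. "The series", "measured", "known", "first", "only" and "open" are said of these compounds alone.

Measured compounds in an ADME assay on Vero 76 cells (Chlorocebus sabaeus) for cytotoxicity, read by crystal violet staining, with a stated time of 96 h; a lower number here means that less compound is tolerated, a higher number that more compound is tolerated:
compound 1, `Fc1ccc(NC(=S)Nc2cccc(C(F)(F)F)c2)cc1`, gives 40000 nM
compound 2, `FC(F)(F)c1cccc(NC(=S)Nc2ccccc2Br)c1`, gives 50000 nM
compound 3, `FC(F)(F)c1cccc(NC(=S)Nc2ccccc2)c1`, gives 39000 nM

All three numbers sit close together. From compound 1 to compound 3 the change is a 1.0-fold lower number from compound 1 to compound 3 (0.01 log units; within the scatter), and from compound 2 to compound 3 it is a 1.3-fold lower number from compound 2 to compound 3 (0.11 log units; within the scatter), so compound 3 cannot be told apart from either on this assay. Among the measured compounds shown here, the one step that leaves compound 3 out, a 1.3-fold higher number from compound 1 to compound 2 (0.10 log units; within the scatter), is likewise within the scatter.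

Compound 4, `Fc1cccc(NC(=S)Nc2cccc(C(F)(F)F)c2)c1`, is reached from compound 3 by fluoro in place of hydrogen on an aromatic carbon. For the measured compounds named here, the step that bears most directly on it is the one from compound 1 to compound 3, in which fluoro was removed from the same kind of ring: a 1.0-fold lower number from compound 1 to compound 3 (0.01 log units; within the scatter). The removal of bromo, a 1.3-fold lower number from compound 2 to compound 3 (0.11 log units; within the scatter), points the same way. Neither halogen on that ring moved this assay beyond its scatter, so no change beyond the scatter is expected for the added fluoro, in either direction; the expected step is no change at the digits printed from compound 3 to compound 4 (within the scatter).

Compound 4 is therefore estimated at 39000 nM, with a range of 20000 nM to 80000 nM.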

Compound 4, half-maximal cytotoxic concentration: 20000 nM
For compound 4 the middle estimate is 2.0-fold (0.29 log units) above the measured one; the measured number falls inside the stated range.
By their numbers in this assay, from the lowest: compounds 4, 3, 1 and 2 (each within the scatter of the next, the first and the last beyond it).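

Working notes on the 3-fluorophenyl change: in this assay, fluoro in place of hydrogen on the phenyl ring gives a 2.0-fold lower number from compound 3 to compound 4 (0.29 log units; within the scatter), and 3-fluorophenyl in place of 4-fluorophenyl gives a 2.0-fold lower number from compound 1 to compound 4 (0.30 log units; within the scatter), so neither adding fluoro at this position nor exchanging the 4-fluorophenyl for the 3-fluorophenyl separates compound 4 from its nearest neighbours. Against the 2-bromophenyl compound the picture differs: 3-fluorophenyl in place of 2-bromophenyl gives a 2.5-fold lower number from compound 2 to compound 4 (0.40 log units; beyond the scatter), the first step in this set to pass the scatter, though only modestly, and it is the only pair involving compound 4 that can be told apart. No measurement at hand accounts for this separation.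

Open, on these data alone, is whether another group in the place fluoro holds in compound 4, such as chloro, methoxy or an amine, would stand clearly apart from compound 3 in this assay. Also open, as far as these compounds go, is whether a carboxylic acid or a nitrile in place of the trifluoromethyl on the other ring would shift the number by more than any step seen so far.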